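The source may report more compounds than this note shows. Statements on the series, on what has been measured and on what is new or still open speak of the compounds shown alone.

Within the data shown here, compound 2, `O=C1NC(=S)S/C1=C\C=C\c1ccccc1OCc1ccccc1`, stands highest of the two compounds measured so far in an assay on isolated protein for inhibition of protein tyrosine phosphatase type IVA 3 (Homo sapiens), tested at 5 ug/mL (a higher number here means more inhibition at the concentration tested (going by the name of the read-out), a lower number less inhibition), where compound 2 gives 49.5%. Among the measured compounds shown here, its only neighbour is compound 1, `O=C1NC(=S)S/C1=C\C=C\c1ccccc1`, and in this assay compound 1 gives 37.4%; the step of a number 12.1 percentage points higher from compound 1 to compound 2 (beyond the scatter) is the one change recorded so far. Compound 3, `O=C1NC(=S)S/C1=C\C=C\c1ccccc1O`, is made from compound 2 by hydrogen in place of benzyl on an oxygen on an aromatic ring, so that most of what entered between compound 1 and compound 2 leaves again. Compound 3 is therefore expected to fall back toward compound 1, by a number 9.5 percentage points lower from compound 2 to compound 3 (within the scatter), and the value estimated for compound 3 in this assay is 40%, within 25% to 55%.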

Compound 3, a percentage reported as inhibition, at one concentration (the size of the read-out at that concentration, not a potency): 51.9%
Compound 3: the middle estimate sits 11.9 percentage points below what was measured; measured number inside the range.
By their numbers in this assay, from the lowest: compound 1; then compounds 2 and 3 (each within the scatter of the next).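

In this assay, the benzyl is dispensable at this place (a number 2.4 percentage points higher from compound 2 to compound 3 (within the scatter)), so the ring it carries is not needed to keep the level of compound 2. Hydroxy in place of hydrogen on the aromatic carbon is enough on its own to give the gain over compound 1 (a number 14.5 percentage points higher from compound 1 to compound 3 (beyond the scatter)), which the earlier pair could not separate from the benzyl. From the compounds shown here alone, whether methoxy, an amine or a carboxylic acid at the same place would read alike stays open, as does the part played by the oxygen itself. Nothing available explains these readings.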